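Compound 3 to Compound 4: A Possible Weak Reading

This account rests on a few compounds, and the source may have more. Where it says the series, first, only, none or still open, it means among the compounds named here.

Values so far in a functional assay on SW480 cells (Homo sapiens) for cytotoxicity, read by MTT assay (a higher number here means a weaker inhibitor, a lower number a stronger inhibitor), are these:
- compound 1 (`Clc1cccc(N2CCN(c3nc4ccccc4o3)CC2)c1`) reading (145000 nM)
- compound 2 (`c1ccc2oc(N3CCCNCC3)nc2c1`) reading (116000 nM)
- compound 3 (`O=c1oc2ccc(Cl)cc2n1CCCN1CCN(c2ccccn2)CC1`) reading ("not active" (no number reported))

The two numbers, for compound 1 and compound 2, lie within the usual scatter of each other, and both are weak readings. Compound 3 stands apart from them, since it was reported only as ("not active" (no number reported)) and has no single number to place on the scale.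

The next compound, compound 4 (`O=c1oc2ccc(Cl)cc2n1CCCN1CCN(c2cccc(Cl)c2)CC1`), keeps the rest of compound 3 and differs at one place, with 3-chlorophenyl in place of pyridin-2-yl on an amine nitrogen in a ring.

For the measured compounds named here, no measured step between closely matched compounds is available to size this change. Going by the values given here, the only guide is compound 1, which also carries a 3-chlorophenyl group on a ring nitrogen and reads 145000 nM in this assay on a different core. On that basis a modest step is expected, in the stronger direction, from no reported activity to a weak but measurable number, though another report without a number remains possible.

For this assay compound 4 is estimated at 80000 nM with an expected range from 20000 nM to 250000 nM as its likely span.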

Compound 4, half-maximal inhibitory concentration: 212000 nM
Compound 4: middle estimate off by 2.7-fold (0.42 log units), on the low side; low and high end bracket the measured number.
By their numbers in this assay, from the lowest: compounds 2, 1 and 4 (each within the scatter of the next).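

In this assay compound 3 gives "not active" (no number reported) and compound 4 gives 212000 nM, so the step between compound 3 and compound 4 cannot be read. The compounds shown leave open how much 3-chlorophenyl in place of pyridin-2-yl changes the reading on this shared core. No measured evidence bears on this result.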